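The source may hold more compounds than are shown below. What is called first, only, known or untested is meant among the compounds shown, and "the series" means these compounds.

The series shares one core, carried by compound 1 `CCOC(=O)c1c(-c2cccc(OC)c2)[nH]c2cc(OC)ccc2c1=O`, compound 2 `CCCOc1cccc(-c2[nH]c3cc(OC)ccc3c(=O)c2C(=O)OCC)c1` and compound 3 `CCOC(=O)c1c(-c2cccc(OC(F)(F)F)c2)[nH]c2cc(OC)ccc2c1=O`. In an ADME assay on HepG2 cells (Homo sapiens) for cytotoxicity, read by luminescence, with a stated time of 72 h (on this read-out higher numbers stand for an effect only at larger amounts of compound and lower numbers for an effect already at smaller amounts), compound 1 reports only a limit of the assay, > 21500 nM. In this assay compound 2 likewise reports only a limit, > 21500 nM. In this assay compound 3 also reports only a limit, > 21500 nM. Compound 3 therefore stands where the rest of the series stands, at the limit of > 21500 nM in this assay, at which 3 of the 3 values shown sit. The measured steps give no readable size: a step that the two limits leave unreadable from compound 1 to compound 2, a step that the two limits leave unreadable from compound 1 to compound 3 and a step that the two limits leave unreadable from compound 2 to compound 3 are each hidden by the two limits. Compound 4 `CCOC(=O)c1c(-c2cccc(NC(C)=O)c2)[nH]c2cc(OC)ccc2c1=O` is not yet measured; it differs from compound 3 by acetamido in place of trifluoromethoxy on an aromatic carbon. Within the data shown here, none of the measured steps bears readably on this change, so no step beyond the scatter is expected, and a limit is again the most probable outcome. For compound 4 in this assay the expected value is 30000 nM, within a range from 15000 nM to 60000 nM. The expected step is a step that the limit leaves unreadable from compound 3 to compound 4, with no direction that the evidence can support.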

Compound 4, half-maximal effective concentration: > 21500 nM
Compound 4: only a limit was reported (the forecaster's own chance of this, stated with the estimate: 80%); the middle value is on the limit's open side.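

In this assay compound 4 reports only a limit, > 21500 nM. Among these compounds, no step linking compound 4 with compound 1, compound 2 or compound 3 can be read: the limit of > 21500 nM in this assay, at which 4 of the 4 values shown sit. The compounds shown leave open whether any substituent change on this aromatic carbon alters the cytotoxic concentration.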